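Stilbene series: E to Z at compound 1

The source may report more compounds than this note shows. Statements on the series, on what has been measured and on what is new or still open speak of the compounds shown alone.

Values so far in a functional assay on HL-60 cells (Homo sapiens) (a higher number here means that more compound is needed for the effect, a lower number that less compound is needed), are these
- Compound 1 `COc1cccc(/C=C/c2cc(OC)cc(OC)c2)c1` gives 70000 nM
- Compound 2 `Cc1ccc(/C=C/c2ccc(O)cc2)cc1C` gives 6000 nM
- Compound 3 `COc1cc(/C=C\c2ccc([N+](=O)[O-])cc2)cc(OC)c1` gives 28000 nM

Compound 1 has the highest number of the three, so more of it is needed than of either other compound. Compound 3 lies nearest to it and compound 2 furthest, and both gaps are beyond the usual scatter.

The next compound to consider is compound 4 `COc1cccc(/C=C\c2cc(OC)cc(OC)c2)c1`, and the change from compound 1 is the two compounds have the same atoms and bonds and differ only in configuration as drawn: 1 of 1 stereo elements differ; a double bond is drawn E in compound 1 and Z in compound 4 with the same atoms and bonds on both sides. A double bond is drawn E in compound 1 and Z in compound 4.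

Among the compounds with values here, no measured pair isolates this change. Within the data shown here, the only guide is compound 3 (28000 nM), whose double bond is also drawn Z and whose number is lower than that of compound 1 (70000 nM). However, these two compounds also differ in their substituents, so this is weak support. A move toward a lower number, of moderate size and beyond the scatter, is expected.

The expected step is a 4.7-fold lower number from compound 1 to compound 4 (0.67 log units; beyond the scatter) on this reasoning, with wide uncertainty. For compound 4 the estimate is 15000 nM with an expected range from 2000 nM to 60000 nM in this assay.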

Compound 4, concentration for half-maximal activity: 5400 nM
The estimate for compound 4 lay 2.8-fold (0.44 log units) above the measured number; measured number inside the range.
By their numbers in this assay, from the lowest: compounds 4 and 2 (each within the scatter of the next); then compound 3; then compound 1.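

In this assay, the double bond of this series proves to be a sensitive point, with configuration alone giving a large change: a 13-fold lower number from compound 1 to compound 4 (1.11 log units; beyond the scatter). Within the data shown here, until now no pair had isolated this change, and compound 3 could bear on it only weakly, as its substituents also differ from those of compound 1; here the methoxy groups stay fixed and the Z form is clearly the one that needs less compound. The step can therefore be assigned to the double bond configuration rather than to any substituent, and the basis for that assignment is: the fact that compounds 1 and 4 differ only in the configuration as drawn.

This single E and Z pair leaves open whether a step of similar direction and size holds on other substitution patterns, including those of compound 2 and compound 3, so no general rule for the series follows from it. It also leaves open how the Z form responds when a methoxy group gives way to an amine or a carboxylic acid, and why the Z form needs less compound remains unresolved.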